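Changing the Amine on the Thiocarbonyl Carbon

The compounds below may be only part of what the source reports. "The series", "measured", "known", "first", "only" and "open" are said of these compounds alone.

Measured so far:
compound 1, `Nc1ccccc1NC(=O)c1ccc(CSC(=S)N2CCN(c3ccc(Cl)cc3)CC2)cc1`: 51.2%
compound 2, `CC1CCCCN1C(=S)SCc1ccc(C(=O)Nc2ccccc2N)cc1`: 45.5%

Of the compounds shown here, two sharing one core have been tested. In a functional assay on HeLa cells (Homo sapiens) for antiproliferative activity, read by CCK-8 assay, with a stated time of 72 h, tested at 2 uM (a lower number here means a weaker effect, a higher number a stronger effect of the compound at the concentration tested), compound 1 gives 51.2%. In the same test compound 2 gives 45.5%, and these two numbers lie within the usual scatter of each other, so nothing separates the two compounds on this evidence. Compound 2 is the point of departure for compound 3, `CN(Cc1cccnc1)C(=S)SCc1ccc(C(=O)Nc2ccccc2N)cc1`, which differs from it in a single place: methyl((pyridin-3-yl)methyl)amino in place of 2-methylpiperidin-1-yl on a thiocarbonyl carbon. One amine on the thiocarbonyl carbon is exchanged for another. Among the compounds with values here, no measured pair shows what such an exchange does here, so no information about direction is available. The expected step is therefore none beyond the scatter, and compound 3 is expected to give 46%, within a range from 30% to 62%. The expected step of a number 0.5 percentage points higher from compound 2 to compound 3 (within the scatter) is estimated to be small.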

Compound 3, a percentage reported as inhibition, at one concentration (the size of the read-out at that concentration, not a potency): 16.4%
Beside the measured number, compound 3's estimate is 29.6 percentage points above it; the whole stated range lies above it.
By their numbers in this assay, from the lowest: compound 3; then compounds 2 and 1 (each within the scatter of the next).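

In this assay, the amine on the thiocarbonyl carbon proves able to change the read-out: methyl((pyridin-3-yl)methyl)amino in place of 2-methylpiperidin-1-yl gives a number 29.1 percentage points lower from compound 2 to compound 3 (beyond the scatter) at the single concentration tested. Within the data shown here, this is the first exchange at this position with a step that can be read, so this position is not indifferent to which amine it carries. The entering group brings an aromatic ring with a hetero atom and a hydrogen-bond acceptor, but no measurement available here explains why the number falls.

From the compounds shown here alone, it remains open whether the fall follows the pyridin-3-yl ring, its ring nitrogen or the loss of the 2-methylpiperidin-1-yl ring. Benzyl(methyl)amino, which has a carbon-only aromatic ring, and unsubstituted piperidin-1-yl on the same thiocarbonyl carbon would help separate these possibilities.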